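The compounds below may be only part of what the source reports. "The series", "measured", "known", "first", "only" and "open" are said of these compounds alone.

Working notes on the series. Three compounds have numbers in an assay for inhibition of MAP kinase-interacting serine/threonine-protein kinase 1 (Homo sapiens), read by luminescence and ADP-Glo, with a stated time of 2 h (a higher number here means a weaker inhibitor, a lower number a stronger inhibitor), so far. Compound 1 `Nc1n[nH]c2cc(-c3ccc(=O)n(Cc4cccc(Cl)c4)c3)ccc12` gives 11 nM. Compound 2 `O=c1ccc(-c2n[nH]c3ncc(Br)cc23)cn1Cc1ccccc1` gives 56 nM. Compound 3 `O=c1ccc(-c2ccc3cn[nH]c3c2)cn1Cc1cccc(C(F)(F)F)c1` gives 40 nM. Compound 3 thus holds the second highest of the three numbers: its nearest neighbour is compound 2, whose number lies within the scatter of it, while compound 1 sits furthest away with a lower number, a gap beyond the scatter. Compound 1 and compound 3 differ in more than one place, so no single change can be read off that pair.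

Compound 4 `O=c1ccc(-c2ccc3cn[nH]c3c2)cn1Cc1cccc(Cl)c1` is yet to be measured. It differs from compound 3 in one place: chloro in place of trifluoromethyl on an aromatic carbon. For the measured compounds named here, no step of this kind has been measured, so the size of the step from compound 3 to compound 4 in this assay is open. The expectation is for at most a modest change, with the number for compound 4 estimated somewhat lower, a step of a 1.6-fold lower number from compound 3 to compound 4 (0.20 log units; within the scatter), because compound 1 carrying the same chloro group on its benzyl gives 11 nM. Compound 4 is therefore estimated at 25 nM, with a range from 9 nM to 70 nM.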

Compound 4, half-maximal inhibitory concentration: 37 nM
Beside the measured number, compound 4's estimate is 1.5-fold (0.17 log units) below it, and the stated range covers the measured number.
By their numbers in this assay, from the lowest: compound 1; then compounds 4, 3 and 2 (each within the scatter of the next).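

In this assay, chloro in place of trifluoromethyl on an aromatic carbon, meta to a large group, gives a 1.1-fold lower number from compound 3 to compound 4 (0.03 log units; within the scatter), so at this place the assay does not tell the two groups apart. For the compounds shown here, with chloro now held fixed, hydrogen in place of amino on an aromatic carbon gives a 3.4-fold higher number from compound 1 to compound 4 (0.53 log units; beyond the scatter), which separates the effect of the amino group from that of the benzyl substituent, a split that the earlier compounds, differing in more than one place, could not provide. No measurement at hand bears on the reason for either step.

From the compounds shown here alone, whether a methoxy group, a nitrile or a carboxylic acid at the chloro place would also leave the number within the scatter remains open. So does whether a methylamino group or a longer amine could stand in for the amino group.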